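Working notes: trifluoromethyl in place of cyano

The source may report more compounds than this note shows. Statements on the series, on what has been measured and on what is new or still open speak of the compounds shown alone.

Measured in a functional assay on KG-1 cells (Homo sapiens) for cytotoxicity, read by luminescence and CellTiter-Glo, with a stated time of 3 days; a higher number here means a weaker inhibitor, a lower number a stronger inhibitor:
compound 1, `N#Cc1ccc(NC(=O)c2ccc(Cl)cc2O)cc1`: 1920 nM
compound 2, `N#Cc1ccc(NC(=O)c2cc(F)ccc2O)cc1`: 2670 nM
compound 3, `O=C(Nc1ccc(C(F)(F)F)cc1)c1cc(F)ccc1O`: 1700 nM

The three values lie close together; none of the gaps between them is beyond the scatter. Compound 1 and compound 2 share the amide but differ in the core; that difference between the two cores is not broken down here. From compound 2 to compound 3 the change is trifluoromethyl in place of cyano on an aromatic carbon, and in this assay this gave a 1.6-fold lower number from compound 2 to compound 3 (0.20 log units; within the scatter). Compound 4, `O=C(Nc1ccc(C(F)(F)F)cc1)c1ccc(Cl)cc1O`, is not yet measured. It comes from compound 1 by the same change, (trifluoromethyl in place of cyano on an aromatic carbon). Among the measured compounds shown here, since the one measured instance of this change, a 1.6-fold lower number from compound 2 to compound 3 (0.20 log units; within the scatter), stayed within the scatter, a step of similar size is expected from compound 1 to compound 4, a 1.5-fold lower number from compound 1 to compound 4 (0.17 log units; within the scatter). Compound 4 is therefore estimated at 1300 nM in this assay, within 600 nM to 2800 nM.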

Compound 4, half-maximal inhibitory concentration: 580 nM
Compound 4: the middle estimate sits 2.2-fold (0.35 log units) above what was measured; measured number outside the range, below it.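

Trifluoromethyl in place of cyano gave a 3.3-fold lower number from compound 1 to compound 4 (0.52 log units; beyond the scatter) in this assay. Set beside the earlier case, both steps run in the same direction and their sizes do not differ beyond the scatter: the same change on two cores in this assay, a 1.6-fold lower number (0.20 log units; within the scatter) from compound 2 to compound 3 and a 3.3-fold lower number (0.52 log units; beyond the scatter) from compound 1 to compound 4, 2.1-fold (0.32 log units) apart, within the scatter of two such steps. Among the compounds shown here, the change therefore carries across these two cores in direction, but only one of the two steps lies beyond the scatter, and two pairs cannot show whether its size depends on the core.

The compounds shown leave open how other groups on this aromatic carbon, such as an amine, a carboxylic acid or a longer chain, would compare with trifluoromethyl. They also leave open whether the same change holds on any further core.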